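From compound 3 to compound 4: furan-2-yl to methyl

The source may report more compounds than this note shows. Statements on the series, on what has been measured and on what is new or still open speak of the compounds shown alone.

- compound 1 `C=C1CC[C@@H]2[C@](C)(COC(=O)c3cccnc3)[C@H](O)CC[C@@]2(C)[C@@H]1/C=C/C1=CCOC1=O` gives 113000 nM
- compound 2 `C=C1CC[C@@H]2[C@](C)(COC(=O)CCCC)[C@H](O)CC[C@@]2(C)[C@@H]1C/C=C1\C=COC1=O` gives 225000 nM
- compound 3 `C=C1CC[C@@H]2[C@](C)(CO)[C@H](OC(=O)c3ccco3)CC[C@@]2(C)[C@@H]1C/C=C1\C=COC1=O` gives 42000 nM

In an ADME assay on HepG2 2.2.15 cells (Homo sapiens) for cytotoxicity, read by MTT assay (a higher number here means that more compound is tolerated, a lower number that less compound is tolerated), compound 3 gives the lowest of the three numbers (42000 nM), and the other two compounds stand higher by more than the scatter. Compound 4 `C=C1CC[C@@H]2[C@](C)(CO)[C@H](OC(C)=O)CC[C@@]2(C)[C@@H]1C/C=C1\C=COC1=O` has methyl in place of furan-2-yl on a carbonyl carbon, so (furan-2-yl)carbonyl gives way to acetyl. Among the compounds with values here, no measured pair differs in one place, so this change has no direct precedent. With compound 3 (42000 nM) already lowest, a moderate step to a higher number in this assay is expected, though a step within the scatter remains possible. The estimate amounts to a 2.1-fold higher number from compound 3 to compound 4 (0.33 log units; beyond the scatter) (expected, not measured). For compound 4 the expected value is 90000 nM (estimated range 35000 nM to 230000 nM).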

Compound 4, half-maximal cytotoxic concentration: 872000 nM
Compound 4: the middle estimate sits 9.7-fold (0.99 log units) below what was measured; measured number above the stated range.
By their numbers in this assay, from the lowest: compound 3; then compounds 1 and 2 (each within the scatter of the next); then compound 4.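

In this assay, within the data shown here, methyl in place of furan-2-yl on a carbonyl carbon gives a 21-fold higher number from compound 3 to compound 4 (1.32 log units; beyond the scatter) and so provides the first one-place comparison. The group on this carbonyl carbon can therefore shift the number far beyond the scatter. No measurement available here accounts for the size of this shift.

Going by these compounds, whether the shift tracks the loss of the five-membered aromatic ring or the drop in group size remains open. Propanoyl or benzoyl on the same carbonyl carbon would help separate these two readings.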